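The source may report more compounds than this note shows. Statements on the series, on what has been measured and on what is new or still open speak of the compounds shown alone.

Within the data shown here, in a functional assay on HEK293 cells for positive allosteric modulation of metabotropic glutamate receptor 5 (Rattus norvegicus), read by fluorescence and calcium flux (a lower number here means a smaller maximal response, a higher number a larger maximal response), compound 3 `Cc1cccc(C#Cc2ccc(C(=O)N[C@H](C)C(C)(C)O)nc2)c1` gives 68.6%, the highest of the three numbers so far, though neither of its steps to the other two compounds reaches beyond the scatter. Compound 1 `C[C@@H](NC(=O)c1ccc(C#Cc2ccc(F)cc2)cn1)C(C)(C)O` gives 66.2% in this assay, and the step of a number 2.4 percentage points higher from compound 1 to compound 3 (within the scatter) lies within the scatter. Compound 2 `Cc1ccccc1C#Cc1ccc(C(=O)N[C@H](C)C(C)(C)O)nc1` gives 59.9%, and the step of a number 8.7 percentage points higher from compound 2 to compound 3 (within the scatter) likewise stays within the scatter, as does a number 6.3 percentage points lower from compound 1 to compound 2 (within the scatter). Compound 4 `C[C@@H](NC(=O)c1ccc(C#Cc2ccc(F)cn2)cn1)C(C)(C)O` differs from compound 3 in one place: 5-fluoropyridin-2-yl in place of 3-methylphenyl on a triple-bonded carbon. All three measured steps bear on this change, since each swaps the aromatic group on the triple-bonded carbon, and none of them moved the maximal response beyond the scatter. Among the measured compounds shown here, none of them, however, brings a ring with a hetero atom into this position, so the 5-fluoropyridin-2-yl group has no precedent among the measured compounds. On the evidence of those three steps, compound 4 is expected to show a step of a number 5.6 percentage points lower from compound 3 to compound 4 (within the scatter) that stays within the scatter. As far as these compounds go, compound 4 is therefore estimated at 63%, with a range from 45% to 80%, set wide because the step of a number 8.7 percentage points higher from compound 2 to compound 3 (within the scatter) already spans most of the scatter and the new ring is untested here.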

Compound 4, largest response reached (reported as efficacy), in percent of the reference or control that the assay uses: 64.6%
Compound 4: middle estimate off by 1.6 percentage points, on the low side; the range from low to high includes it.
By their numbers in this assay, from the lowest: compounds 2, 4, 1 and 3 (each within the scatter of the next).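

The aromatic group on the triple-bonded carbon now carries a ring with a hetero atom and a hydrogen-bond acceptor, which 3-methylphenyl lacks, and in this assay the data show a number 4 percentage points lower from compound 3 to compound 4 (within the scatter) together with a number 4.7 percentage points higher from compound 2 to compound 4 (within the scatter) and a number 1.6 percentage points lower from compound 1 to compound 4 (within the scatter) for this replacement. The position therefore takes 5-fluoropyridin-2-yl as well as the three carbon-only rings, and all four compounds sit within the scatter of one another, so no group at this position stands apart from the others in maximal response. Nothing available explains why the maximal response stays in this range.

All four groups on the triple-bonded carbon are six-membered aromatic rings, so the compounds shown leave open whether a saturated ring such as cyclohexyl, a longer chain such as n-butyl, or a ring bearing an amine or a carboxylic acid would keep the response in this assay or move it beyond the scatter. They also leave open whether a pyrimidine ring, with a second ring nitrogen, would behave as 5-fluoropyridin-2-yl does.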